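Swapping the Difluoropiperidine for a Hydroxypyrrolidine

The source may hold more compounds than are shown below. What is called first, only, known or untested is meant among the compounds shown, and "the series" means these compounds.

Measured in a physicochemical assay for solubility, read by HPLC, in phosphate buffer, at pH 6.5; a higher number here means a more soluble compound, a lower number a less soluble compound:
- compound 1 `COC(=O)C1=C(C)NC(c2nccs2)=NC1(C)c1ccc(F)cc1`: 22 ug/mL
- compound 2 `COC(=O)C1=C(CN2CCC(F)(F)CC2)NC(c2nccs2)=NC1(C)c1ccc(F)cc1`: < 1 ug/mL (a limit)

Compound 2 gives only a limit of the assay, < 1 ug/mL, and no number.

Compound 3 `COC(=O)C1=C(CN2CCC(O)C2)NC(c2nccs2)=NC1(C)c1ccc(F)cc1` carries 3-hydroxypyrrolidin-1-yl in place of 4,4-difluoropiperidin-1-yl on a saturated chain carbon bound to a double-bonded ring carbon.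

Going by the values given here, the one measured step bearing on this is an at least 22-fold lower number from compound 1 to compound 2 (1.34 log units; beyond the scatter), a large one, with 4,4-difluoropiperidin-1-yl entering in place of hydrogen. That group leaves again here, so compound 3 is expected to move back toward compound 1 at 22 ug/mL. Among the compounds with values here, no measured step covers the entering group, and the starting point is only a limit, so the size stays uncertain. A higher number is expected, with an at least 15-fold higher number from compound 2 to compound 3 (1.17 log units; beyond the scatter) as the estimated step. For compound 3 the expected value is 15 ug/mL, with an estimated range from 3 ug/mL to 80 ug/mL.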

Compound 3, solubility: 503 ug/mL
Compound 3: the middle estimate sits 34-fold (1.53 log units) below what was measured, and the stated range ends below it.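

In this assay, going by these compounds alone, substitution on the saturated chain carbon bound to a double-bonded ring carbon can go either way: where the earlier compounds showed only a fall, 3-hydroxypyrrolidin-1-yl gives a 23-fold higher number from compound 1 to compound 3 (1.36 log units; beyond the scatter). The outcome at this place therefore depends on which group enters and not merely on a group being there, as the exchange of one ring for the other shows with an at least 500-fold higher number from compound 2 to compound 3 (2.70 log units; beyond the scatter). Compound 2 gives a limit and not a number, so the true size of that exchange stays open: the limit of < 1 ug/mL in this assay, at which 1 of the 3 values shown sits.

The exchange replaces a six-membered ring carrying two fluorines with a five-membered ring carrying a hydroxyl, and the compounds shown do not separate ring size from the hydroxyl. Pyrrolidin-1-yl without the hydroxyl, or 4-hydroxypiperidin-1-yl, would divide the two.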